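This account rests on a few compounds, and the source may have more. Where it says the series, first, only, none or still open, it means among the compounds named here.

In a functional assay on SK-BR-3 cells (Homo sapiens) for cytotoxicity, read by MTT assay, with a stated time of 72 h (a lower number here means a stronger inhibitor, a higher number a weaker inhibitor), compound 1 `Nc1cccc(Nc2c(C(=O)NCc3ccc(F)cc3)nc(Br)c3cccnc23)c1` gives > 10000 nM, which is a limit of the assay and not a number. Compound 2 `Nc1ccc(Nc2c(C(=O)NCc3ccc(F)cc3)nc(Br)c3cccnc23)cc1` gives 4000 nM, and compound 3 `N[C@H]1CC[C@H](Nc2c(C(=O)NCc3ccc(F)cc3)nc(Br)c3cccnc23)CC1` gives 2000 nM. Compound 3 therefore has the lowest actual number, but it stands level with compound 2, with a 2.0-fold lower number from compound 2 to compound 3 (0.30 log units; within the scatter). The other steps are an at least 2.5-fold lower number from compound 1 to compound 2 (0.39 log units; beyond the scatter) and an at least 5.0-fold lower number from compound 1 to compound 3 (0.69 log units; beyond the scatter). Compound 4 `C[C@H](NC(=O)c1nc(Br)c2cccnc2c1N[C@H]1CC[C@H](N)CC1)c1ccc(F)cc1` differs from compound 3 by methyl in place of hydrogen on a saturated chain carbon bound to an amide-type nitrogen and an aromatic carbon. All three measured steps exchange the amine-bearing group, so none of them sizes this change, and no step beyond the scatter is expected in this assay. The estimated step is a 1.3-fold higher number from compound 3 to compound 4 (0.10 log units; within the scatter). Compound 4 is expected at 2500 nM, with an estimated range from 800 nM to 8000 nM.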

Compound 4, half-maximal inhibitory concentration: 9000 nM
For compound 4 the middle estimate is 3.6-fold (0.56 log units) below the measured one; the whole stated range lies below it.
By their numbers in this assay, from the lowest: compounds 3 and 2 (each within the scatter of the next); then compound 4. At a limit, above all of these: compound 1.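

Among these compounds, with a 4.5-fold higher number from compound 3 to compound 4 (0.65 log units; beyond the scatter), this is the first change outside the amine-bearing group, and it shows that a single added methyl on the saturated chain carbon bound to an amide-type nitrogen and an aromatic carbon is enough to raise the number beyond the scatter. The 4-fluorobenzyl part therefore responds to even this small change. Little room remains above compound 4 in this assay: the limit of > 10000 nM in this assay, at which 1 of the 4 values shown sits.

On these data alone, how an ethyl or hydroxymethyl group on that same carbon would compare stays open. So does whether the methyl has a similar effect alongside the 4-aminophenyl group of compound 2.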